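Phenyl Replacing 3-Fluoro-4-hydroxyphenyl: What Compound 4 Might Give

The source may report more compounds than this note shows. Statements on the series, on what has been measured and on what is new or still open speak of the compounds shown alone.

Compound 1 `CN(C)CCn1cnnc1-c1cc(Oc2ccc(NC(=O)N/N=C/c3ccc(O)c(F)c3)cc2F)ccn1`: 3310 nM in a functional assay on HT-29 cells (Homo sapiens) for cytotoxicity, read by MTT assay, with a stated time of 72 h; a higher number here means a weaker inhibitor, a lower number a stronger inhibitor
Compound 2 `CN(C)CCn1cnnc1-c1cc(Oc2ccc(NC(=O)N/N=C/c3ccc(O)cc3)cc2F)ccn1`: 1920 nM in this assay
Compound 3 `Cn1ncnc1-c1cc(Oc2ccc(NC(=O)N/N=C/c3ccccc3)cc2F)ccn1`: 30200 nM in this assay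

Compound 1 stands second highest of the three numbers; compound 2 is nearest (a 1.7-fold lower number from compound 1 to compound 2 (0.24 log units; within the scatter)), and compound 3 is furthest, beyond the scatter. Compound 4 `CN(C)CCn1cnnc1-c1cc(Oc2ccc(NC(=O)N/N=C/c3ccccc3)cc2F)ccn1` differs from compound 1 by phenyl in place of 3-fluoro-4-hydroxyphenyl on a carbon with a double bond to nitrogen. Going by the values given here, no measured step removes the hydroxyl group on this core; the only step recorded, from compound 1 to compound 2, is within the scatter. Compound 3, which carries phenyl on a different core, gives the highest number shown, so a weaker result is expected for compound 4, as a 2.4-fold higher number from compound 1 to compound 4 (0.38 log units; beyond the scatter). Compound 4 is therefore estimated at 8000 nM, within 2500 nM to 25000 nM.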

Compound 4, half-maximal inhibitory concentration: 1120 nM
For compound 4 the middle estimate is 7.1-fold (0.85 log units) above the measured one; the whole stated range lies above it.
By their numbers in this assay, from the lowest: compounds 4, 2 and 1 (each within the scatter of the next, the first and the last beyond it); then compound 3.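

On this core, phenyl on the carbon with a double bond to nitrogen costs nothing in this assay: dropping the whole 3-fluoro-4-hydroxyphenyl group gives a stronger result (a 3.0-fold lower number from compound 1 to compound 4 (0.47 log units; beyond the scatter)). Hydrogen in place of hydroxy alone stays within the scatter (a 1.7-fold lower number from compound 2 to compound 4 (0.23 log units; within the scatter)), so the hydroxy group is not needed here. With phenyl held fixed, the high number of compound 3 goes with its other triazolyl group (a 27-fold lower number from compound 3 to compound 4 (1.43 log units; beyond the scatter)). Nothing shown explains these steps. From the compounds shown here alone, whether an amine or a carboxylic acid on the phenyl ring would keep this level remains open.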